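A few compounds are considered here, and "the series" means these few. Any claim that something is new, unique, unknown or untested is made for them only; others in the source may bear on it.

Measured compounds:
compound 1, `CN1C(=S)N(C2CCCCC2)C(=O)/C1=C/c1ccc(O)cc1O`, 26000 nM
compound 2, `CN1C(=S)N(C2CCCCC2)C(=O)/C1=C/c1cccc(O)c1O`, 7390 nM

Both numbers come from an assay for inhibition of NADPH oxidase 1 (Homo sapiens), read by chemiluminescence; on this read-out lower numbers stand for stronger inhibition and higher numbers for weaker inhibition. Compound 1 gives 26000 nM in this assay, the higher of the two values seen; compound 2 sits lower, and the gap between the two lies beyond the usual scatter of repeated measurements. Within the data shown here, no step between these two compounds is worked out here, so only their two values are set side by side.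

Compound 3, `Cc1ccc(N2C(=O)/C(=C/c3ccc(O)cc3O)N(C)C2=S)cc1`, has not yet been measured in this assay. It differs from compound 1 in one place: 4-methylphenyl in place of cyclohexyl on an amide-type nitrogen in a ring. Among the measured compounds shown here, no measured pair shows the effect of such a change, so compound 3 is expected to land close to compound 1, with a step from compound 1 to compound 3 of a 1.3-fold lower number from compound 1 to compound 3 (0.11 log units; within the scatter), not clearly beyond the scatter in either direction. Compound 3 is thus estimated at 20000 nM in this assay, within a range of 6000 nM to 70000 nM.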

Compound 3, inhibition constant: 27100 nM
For compound 3 the middle estimate is 1.4-fold (0.13 log units) below the measured one, and the stated range covers the measured number.
By their numbers in this assay, from the lowest: compound 2; then compounds 1 and 3 (each within the scatter of the next).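

In this assay the change from cyclohexyl to 4-methylphenyl on the amide-type nitrogen in the ring gives a 1.0-fold higher number from compound 1 to compound 3 (0.02 log units; within the scatter) and so offers the first single-place comparison among these compounds. At this position, this one pair does not separate the non-aromatic carbon ring from the aromatic one, even with the added methyl group. Nothing measured here bears on why the two groups read alike. The compounds shown leave open whether a different group on this nitrogen, such as a longer alkyl chain, an amine or a carboxylic acid, would move the number beyond the scatter. They also leave open whether the same change would read alike when made on compound 2 rather than on compound 1.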